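The compounds below may be only part of what the source reports. "The series", "measured", "known", "first", "only" and "open" are said of these compounds alone.

Compound 1 `CN1CCC(n2cc(S(=O)(=O)c3ccc(F)cc3)c3cccnc32)C1` carries a fluoro group on its aryl ring and in a functional assay on HeLa cells for antagonist activity at 5-hydroxytryptamine receptor 6 (Homo sapiens), read by cAMP accumulation and immunoassay (on this read-out lower numbers stand for stronger inhibition and higher numbers for weaker inhibition), compound 1 gives 213 nM. Compound 2 `CN1CCC(n2cc(S(=O)(=O)c3ccc(Cl)cc3)c3cccnc32)C1` differs from compound 1 only by chloro in place of fluoro on an aromatic carbon, and in this assay compound 2 gives 95 nM; that change brought a 2.2-fold lower number from compound 1 to compound 2 (0.35 log units; beyond the scatter). Compound 3 `CCN1CCC(n2cc(S(=O)(=O)c3cccc(F)c3)c3cccnc32)C1` has a different core, and the difference between the core of compound 3 and that of compound 1 is not broken down here. In this assay compound 3 gives 132 nM, a number lying within the usual scatter of both compound 2 and compound 1, so no order among these three can be drawn from it. Compound 4 `CCN1CCC(n2cc(S(=O)(=O)c3cccc(Cl)c3)c3cccnc32)C1` is related to compound 3 by chloro in place of fluoro on an aromatic carbon. This is the same kind of change as that from compound 1 to compound 2, though the place differs: in the earlier pair the group stands para to a large group, here it stands meta to a large group. On that kind of change alone, compound 4 is expected to show a step of a 1.9-fold lower number from compound 3 to compound 4 (0.28 log units; within the scatter) in this assay, due to a 2.2-fold lower number from compound 1 to compound 2 (0.35 log units; beyond the scatter) seen in the earlier pair, with the different place leaving the expectation uncertain. Compound 4 is therefore estimated at 70 nM, within 35 nM to 150 nM.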

Compound 4, half-maximal inhibitory concentration: 120 nM
For compound 4 the middle estimate is 1.7-fold (0.23 log units) below the measured one, within the range that was stated.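

Carried to the core of compound 3, chloro in place of fluoro on an aromatic carbon gives a 1.1-fold lower number from compound 3 to compound 4 (0.04 log units; within the scatter) in this assay and so leaves no difference that can be claimed on that core. Set beside the earlier pair, the two steps cannot be told apart: the same change on two cores in this assay, a 2.2-fold lower number (0.35 log units; beyond the scatter) from compound 1 to compound 2 and a 1.1-fold lower number (0.04 log units; within the scatter) from compound 3 to compound 4, 2.0-fold (0.31 log units) apart, within the scatter of two such steps. This shows that the step seen on the core of compound 1 is not contradicted on the core of compound 3, but it does not show that the change carries over, since each core offers a single pair, the group stands at a different place in the two pairs, and the second step is itself within the scatter.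

The compounds shown leave open how a methoxy or trifluoromethyl group would compare with fluoro and chloro at either place on the aryl ring. They also leave open whether the step would look the same with a longer chain in place of the methyl or ethyl group on the amine nitrogen.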